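Swapping the sulfur-linked aryl for a methylphenoxy group

The compounds below may be only part of what the source reports. "The series", "measured", "known", "first", "only" and "open" are said of these compounds alone.

Compound 1 `CC(C)C[C@H](N)c1cc(C(F)(F)F)ccc1N1CCN(C(=O)CSc2ccc(Cl)cc2Cl)CC1` is the weaker of the two measured compounds: in an assay on HEK293 cells for displacement of a labelled ligand from Melanocortin receptor 4 (Homo sapiens) (a higher number here means a weaker inhibitor, a lower number a stronger inhibitor), compound 1 gives 1500 nM, while compound 2 `CC(C)C[C@H](N)c1cc(C(F)(F)F)ccc1N1CCN(C(=O)C(C)Cc2ccc(Cl)cc2)CC1` gives 47 nM, and the step of a 32-fold lower number from compound 1 to compound 2 (1.50 log units; beyond the scatter) shows that replacing the whole side chain can change potency strongly. Compound 3 `Cc1ccc(OCC(=O)N2CCN(c3ccc(C(F)(F)F)cc3[C@@H](N)CC(C)C)CC2)cc1` differs from compound 1 by 4-methylphenoxy in place of (2,4-dichlorophenyl)sulfanyl on a saturated chain carbon bound to a carbonyl carbon. Going by the values given here, no measured step tests this exact change, and the heteroatom-linked arrangement of compound 1 is kept, so only a modest improvement is expected, a 2.1-fold lower number from compound 1 to compound 3 (0.33 log units; beyond the scatter). Compound 3 is therefore estimated at 700 nM, within a range from 200 nM to 2500 nM.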

Compound 3, inhibition constant: 4400 nM
Compound 3: the middle estimate sits 6.3-fold (0.80 log units) below what was measured; the whole stated range lies below it.
By their numbers in this assay, from the lowest: compound 2; then compound 1; then compound 3.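

Putting 4-methylphenoxy on this saturated chain carbon gives a 2.9-fold higher number from compound 1 to compound 3 (0.47 log units; beyond the scatter) and so lowers binding rather than improving it. Replacing (4-methylphenoxy)methyl's counterpart, the 1-(4-chlorobenzyl)ethyl group, gives a 94-fold higher number from compound 2 to compound 3 (1.97 log units; beyond the scatter) and shows that compound 2 remains far ahead of both compounds with an atom-linked aryl group. Nothing available explains either step.

In compound 3 the linking atom and the ring substituents change together, so it remains open which of them accounts for the difference from compound 1. A 2,4-dichlorophenoxy group at this position would separate the two.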